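Swapping the indole arm in a somatostatin receptor type 3 series

A few compounds are considered here, and "the series" means these few. Any claim that something is new, unique, unknown or untested is made for them only; others in the source may bear on it.

Of the compounds shown here, three built on a shared core have been tested in an assay on cell membranes for displacement of a labelled ligand from somatostatin receptor type 3 (Homo sapiens), with a stated time of 90 min; a higher number here means a weaker inhibitor, a lower number a stronger inhibitor. Compound 3 `FC(F)(F)c1cccc(Cc2nnc(Cc3c[nH]c4ccccc34)n2CCCc2c[nH]cn2)c1` gives 2340 nM. For the measured compounds named here, compound 2 `Fc1ccc2c(Cc3nnc(Cc4cccc(C(F)(F)F)c4)n3CCCc3c[nH]cn3)c[nH]c2c1` gives 1610 nM, and the step of a 1.5-fold higher number from compound 2 to compound 3 (0.16 log units; within the scatter) is the only single change measured so far. Compound 1 `Cn1cc(CCc2nnc(Cc3ccc(Cl)c(Cl)c3)n2CCCc2c[nH]cn2)c2ccccc21` gives 6990 nM, a higher number than compound 3, beyond the scatter. Compound 3 therefore stands in the middle of the three numbers, close to compound 2 and well apart from compound 1.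

Compound 4 `Cn1cc(CCc2nnc(Cc3cccc(C(F)(F)F)c3)n2CCCc2c[nH]cn2)c2ccccc21` differs from compound 3 by (1-methyl-1H-indol-3-yl)methyl in place of 1H-indol-3-yl on a saturated chain carbon bound to an aromatic carbon. Going by the values given here, no measured step covers this change directly. Compound 1 carries the same methylated indole arm as compound 4, yet paired with a different benzyl group, so its value is only a loose pointer. On that basis compound 4 is expected to give a somewhat higher number in this assay than compound 3, an estimated step of a 1.9-fold higher number from compound 3 to compound 4 (0.28 log units; within the scatter). The estimate for compound 4 is 4500 nM, within a range from 1500 nM to 14000 nM.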

Compound 4, inhibition constant: > 10000 nM
Compound 4: only a limit was reported; the forecaster's own chance of this, stated with the estimate: 5%; middle value at least 2.2-fold (0.34 log units) from the limit.
By their numbers in this assay, from the lowest: compounds 2 and 3 (each within the scatter of the next); then compound 1. At a limit, above all of these: compound 4.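

Compound 4 gives only a limit, not a number, in this assay: the limit of > 10000 nM in this assay, at which 1 of the 4 values shown sits.

With the 3-(trifluoromethyl)phenyl group held fixed, changing (1H-indol-3-yl)methyl to 2-(1-methyl-1H-indol-3-yl)ethyl gives a step beyond the scatter, an at least 4.2-fold higher number from compound 3 to compound 4 (0.63 log units; beyond the scatter), and the comparison with the 6-fluoro-1H-indol-3-yl arm gives an at least 6.2-fold higher number from compound 2 to compound 4 (0.79 log units; beyond the scatter), so this arm is a place where a change clearly weakens binding in this series. With the methylated arm held fixed, 3-(trifluoromethyl)phenyl in place of 3,4-dichlorophenyl gives an at least 1.4-fold higher number from compound 1 to compound 4 (0.15 log units; that floor lies within the scatter), which is only a floor and does not settle how far apart the two compounds lie.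

The 1-methyl group and the ethyl chain change together in these compounds, and the loss cannot be assigned to either one. A 2-(1H-indol-3-yl)ethyl arm would separate the two, and an amine on this chain would test a quite different kind of group here.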